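Methoxycarbonyl in place of methylsulfonyl on an aromatic carbon

The source may hold more compounds than are shown below. What is called first, only, known or untested is meant among the compounds shown, and "the series" means these compounds.

In a physicochemical assay for solubility, read by spectrophotometry, in phosphate buffer, with a stated time of 18 h, at pH 7.4 (a lower number here means a less soluble compound, a higher number a more soluble compound), compound 1 `CCc1ccc(-c2nc3c(c(C)nn3-c3ccccc3)c(-c3ccccc3I)c2C#N)cc1` gives 8500 nM. For the measured compounds named here, compound 2 `CCc1ccc(-c2nc3c(c(C)nn3-c3ccccc3)c(-c3ccccc3S(C)(=O)=O)c2C#N)cc1` gives 2200 nM, the lower of the two numbers so far. Going by the values given here, the only measured step is a 3.9-fold lower number from compound 1 to compound 2 (0.59 log units; beyond the scatter), and it comes with methylsulfonyl in place of iodo on an aromatic carbon. Compound 3 `CCc1ccc(-c2nc3c(c(C)nn3-c3ccccc3)c(-c3ccccc3C(=O)OC)c2C#N)cc1` keeps the shared core but carries methoxycarbonyl in place of methylsulfonyl, on an aromatic carbon ortho to a large group: methoxycarbonyl in place of methylsulfonyl on an aromatic carbon. Among the compounds with values here, no compound measured so far carries methoxycarbonyl, so the earlier step offers only a rough scale, at the same place on the molecule. With methylsulfonyl now leaving, a smaller step upward in this assay seems the likeliest outcome, and it may not clear the scatter. The expected change is a 1.6-fold higher number from compound 2 to compound 3 (0.20 log units; within the scatter). For compound 3 the estimated value is 3500 nM, within an expected range of 1200 nM to 10000 nM.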

Compound 3, solubility: 17000 nM
The estimate for compound 3 lay 4.9-fold (0.69 log units) below the measured number; measured number outside the range, above it.
By their numbers in this assay, from the lowest: compound 2; then compounds 1 and 3 (each within the scatter of the next).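

In this assay, methoxycarbonyl in place of methylsulfonyl gives a 7.7-fold higher number from compound 2 to compound 3 (0.89 log units; beyond the scatter) and so shows that this position responds clearly to the choice of group, even though both groups have the same count of heavy atoms and of hydrogen-bond acceptors. For the compounds shown here, the comparison of the iodo and methoxycarbonyl compounds gives a 2.0-fold higher number from compound 1 to compound 3 (0.30 log units; within the scatter) and so does not separate these two groups, which leaves compound 2 as the one compound set apart by steps beyond the scatter. No measurement of another property bears on this result, so its cause stays unknown.

The compounds shown leave open how an amine or a carboxylic acid would read at this same place. They also leave open whether a longer chain in place of the methyl of methoxycarbonyl would keep the number of compound 3 17000 nM or change it.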